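Para substituent swap on the shared thiosemicarbazone-type core

This account rests on a few compounds, and the source may have more. Where it says the series, first, only, none or still open, it means among the compounds named here.

Title check: the core is not named in the data, so the title below replaces it.

Replacing the para nitrile with trifluoromethyl

In a functional assay on HeLa cells (Homo sapiens) for antiproliferative activity, read by sulforhodamine B assay, with a stated time of 72 h (a lower number here means a stronger inhibitor, a higher number a weaker inhibitor), compound 1 `Fc1ccccc1NC(=S)N/N=C/c1ccc2ccccc2n1` gives > 100000 nM, which is a limit of the assay and not a number. Going by the values given here, compound 2 `N#Cc1ccc(NC(=S)N/N=C/c2ccc3ccccc3n2)cc1` gives 20000 nM, the only true number so far.

The next compound is compound 3 `FC(F)(F)c1ccc(NC(=S)N/N=C/c2ccc3ccccc3n2)cc1`, with trifluoromethyl in place of cyano on an aromatic carbon, para to a large group (trifluoromethyl in place of cyano on an aromatic carbon).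

Among the compounds with values here, one measured step bears on this change, and only indirectly: an at least 5.0-fold lower number from compound 1 to compound 2 (0.69 log units; beyond the scatter). It is at least modest and beyond the scatter, but one end of it is a limit. It exchanges 2-fluorophenyl for 4-cyanophenyl, so it does not test cyano against trifluoromethyl.

The expectation is therefore anchored on compound 2 at 20000 nM, and no step beyond the scatter is expected in this assay, with the direction left open. The estimated change is a 1.1-fold lower number from compound 2 to compound 3 (0.05 log units; within the scatter).

For compound 3 the expected value is 18000 nM, with an estimated range of 5000 nM to 70000 nM.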

Compound 3, half-maximal inhibitory concentration: 59100 nM
Compound 3: middle estimate off by 3.3-fold (0.52 log units), on the low side; measured number inside the range.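

In this assay, trifluoromethyl in place of cyano on the aromatic carbon para to a large group gives a 3.0-fold higher number from compound 2 to compound 3 (0.47 log units; beyond the scatter), so this position does not treat the two groups alike. Both ends of this step are true numbers, and it compares two groups at one position on the shared core, which the earlier step from 2-fluorophenyl to 4-cyanophenyl could not do. Compound 1 remains a limit of the assay and not a number, so this is the only step in the series with a number at each end: the limit of > 100000 nM in this assay, at which 1 of the 3 values shown sits.

Open, going by these compounds, is how an amine, a carboxylic acid or a methoxy group on the same aromatic carbon would compare with cyano, and whether any such group would give a lower number than compound 2 does. A single pair also gives only the order of these two groups at this position, and it leaves open which feature of either group accounts for the step and whether the same order would hold with other changes elsewhere on the core.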